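Shortening the amide group of compound 2

The source may hold more compounds than are shown below. What is called first, only, known or untested is meant among the compounds shown, and "the series" means these compounds.

Compounds measured so far in a physicochemical assay for lipophilicity, at pH 7.4; a lower number here means a more polar compound, a higher number a more lipophilic compound
- compound 1 `CNC(=O)c1cc(C(=O)N[C@H]2CC[C@H](O)CC2)cc2c1OC[C@@]2(C)c1ccccc1` at 3.3
- compound 2 `CNC(=O)c1cc(C(=O)NC2CC2)cc2c1OC[C@@]2(C)c1ccccc1` at 4

Compound 2 at 4 stands highest of the two measured compounds. Compound 3 `CNC(=O)c1cc(C(=O)NC)c2c(c1)[C@](C)(c1ccccc1)CO2` has not yet been measured and differs from it as follows: methyl in place of cyclopropyl on an amide-type nitrogen with methyl in place of cyclopropyl on an amide-type nitrogen. Among the measured compounds shown here, the one measured step at that nitrogen is a number 0.70 log units higher from compound 1 to compound 2 (beyond the scatter) and it is modest and beyond the scatter, though it concerns a different group. The estimated step is a number 0.50 log units lower from compound 2 to compound 3 (beyond the scatter) in this assay and so a modest fall is expected. Compound 3 is estimated at 3.5 with an expected range of 3.1 to 3.9 in this measurement.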

Compound 3, distribution coefficient: 3.4
Estimate against measurement, compound 3: 0.10 log units above; measured number inside the range.
By their numbers in this assay, from the lowest: compounds 1 and 3 (each within the scatter of the next); then compound 2.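

In this assay the nitrogen of this amide also responds to a small change between two plain carbon groups: methyl in place of cyclopropyl gives a number 0.60 log units lower from compound 2 to compound 3 (beyond the scatter) on this position. Methyl and 4-hydroxycyclohexyl cannot be told apart here, with a number 0.10 log units higher from compound 1 to compound 3 (within the scatter) despite the difference between the two groups. Nothing measured explains either step.

The compounds shown leave open where an ethyl or isopropyl group would fall on this nitrogen. They also leave open what an amine or a carboxylic acid on a longer chain would do there.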